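Dropping an aromatic methyl: microsomal stability notes

The source may hold more compounds than are shown below. What is called first, only, known or untested is meant among the compounds shown, and "the series" means these compounds.

Measured compounds and their numbers:
- compound 1 `Cc1cc(-c2ccnc(C(F)F)c2)ncc1OC[C@@](C)(N)CC(C)C`: 80%
- compound 2 `CC(=O)Nc1cc(-c2cc(F)c(OC[C@@H](N)CC(C)C)cc2F)ccn1`: 70%
- compound 3 `COC(=O)Nc1cc(-c2cnc(OC[C@@](C)(N)CC(C)C)cc2C)ccn1`: 69%

In an ADME assay on microsomes from liver (Mus musculus) for metabolic stability, read by LC-MS, using NADPH, with a stated time of 10 min, tested at 0.5 uM (on this read-out lower numbers stand for a less stable compound and higher numbers for a more stable compound), compound 1 gives 80%, compound 2 gives 70% and compound 3 gives 69%. Compound 3 carries the lowest of the three numbers, but its gap to compound 2 lies within the scatter, so the two cannot be told apart; only compound 1 stands beyond the scatter above compound 3.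

Compound 4 `COC(=O)Nc1cc(-c2ccc(OC[C@@](C)(N)CC(C)C)nc2)ccn1` differs from compound 3 in one place: hydrogen in place of methyl on an aromatic carbon. For the measured compounds named here, no pair of measured compounds differs in a single place, so no measured step is available as a guide for this change. With three compounds that differ from one another in several places at once, the data give no ground to expect a move beyond the scatter; the step of a number 1 percentage points higher from compound 3 to compound 4 (within the scatter) is therefore expected to be small and of no clear direction. In this assay compound 4 is estimated at 70%, with a range from 55% to 85%.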

Compound 4, percent of the compound remaining: 79%
Estimate against measurement, compound 4: 9 percentage points below, within the range that was stated.
By their numbers in this assay, from the lowest: compounds 3, 2, 4 and 1 (each within the scatter of the next, the first and the last beyond it).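

In this assay, for the compounds shown here, hydrogen in place of methyl on an aromatic carbon, ortho to a large group and opposite the ring nitrogen, gives a number 10 percentage points higher from compound 3 to compound 4 (within the scatter), the first comparison that differs in one place. On this single pair, the methyl at this position is not shown to be needed for the read-out, since compound 3 and compound 4 cannot be told apart. No measurement at hand bears on the reason for this outcome.

Going by these compounds, what a larger group on this carbon, such as ethyl, methoxy or chlorine, would do to the percent of compound remaining stays open. Also open, on these data alone, is whether the same exchange of methyl for hydrogen on the core of compound 1 would read the same way.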